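Piperidin-1-yl in place of isopropoxycarbonyl on a shared core

This account rests on a few compounds, and the source may have more. Where it says the series, first, only, none or still open, it means among the compounds named here.

Of the compounds shown here, three sharing one core have been read in a toxicity assay on NIH3T3 cells (Mus musculus) for cytotoxicity, read by resazurin assay (a lower number here means that less compound is needed, a higher number that more compound is needed for the effect), and none of them has yet given a number. Compound 1 (`CCOC(=O)c1ccc(NCc2cncn2Cc2ccc(-c3ccccc3)cc2)cc1-c1ccccc1`) gives > 10000 nM, which is a limit. Compound 2 (`c1ccc(-c2ccc(Cn3cncc3CNc3ccc(-c4cncs4)c(-c4ccccc4)c3)cc2)cc1`) gives > 1000 nM, which is also a limit. Compound 3 (`CC(C)OC(=O)c1ccc(NCc2cncn2Cc2ccc(-c3ccccc3)cc2)cc1-c1ccccc1`) gives > 10000 nM, again only a limit.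

Compound 4 (`c1ccc(-c2ccc(Cn3cncc3CNc3ccc(N4CCCCC4)c(-c4ccccc4)c3)cc2)cc1`) remains unmeasured. It carries piperidin-1-yl in place of isopropoxycarbonyl on an aromatic carbon, ortho to a phenyl group: piperidin-1-yl in place of isopropoxycarbonyl on an aromatic carbon.

Two measured steps exchange the group on this same aromatic carbon: a step that the two limits leave unreadable from compound 1 to compound 2 and a step that the two limits leave unreadable from compound 2 to compound 3. A third, a step that the two limits leave unreadable from compound 1 to compound 3, touches only the chain bound to the oxygen. None of the three has a readable size, so they offer no direction for the new exchange. No step beyond the scatter is therefore expected in this assay, and the most likely report for the new compound is another limit.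

The expected change is a step that the limit leaves unreadable from compound 3 to compound 4. The estimate for compound 4 is 12000 nM, with an expected range from 3000 nM to 40000 nM.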

Compound 4, half-maximal effective concentration: > 1000 nM
Compound 4: a limit, no number (the forecaster's own chance of this, stated with the estimate: 75%); the middle value is on the limit's open side.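

In this assay compound 4 gives > 1000 nM, which is a limit and not a number. The steps linking compound 4 with compound 1, compound 2 and compound 3 cannot be read. The compounds shown leave open whether exchanging the group on this aromatic carbon changes the concentration needed in this assay at all.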